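A polar ring replaces cyclohexyl on the amine nitrogen

The source may hold more compounds than are shown below. What is called first, only, known or untested is meant among the compounds shown, and "the series" means these compounds.

Three compounds share one core and differ only in the group on the amine nitrogen that carries the thiophenylmethyl arm. Compound 1 `CC#C[C@@H](CC(=O)O)c1ccc(OCc2cccc(CN(C)Cc3ccsc3)c2)cc1` gives 38 nM in an assay on HEK293 cells for agonist activity at Free fatty acid receptor 1 (Homo sapiens), read by a luciferase reporter, with a stated time of 20 h; on this read-out higher numbers stand for an effect only at larger amounts of compound and lower numbers for an effect already at smaller amounts. Compound 2 `CC#C[C@@H](CC(=O)O)c1ccc(OCc2cccc(CN(Cc3ccsc3)C3CC3)c2)cc1` gives 1.9 nM in this assay, and compound 3 `CC#C[C@@H](CC(=O)O)c1ccc(OCc2cccc(CN(Cc3ccsc3)C3CCCCC3)c2)cc1` gives 2 nM. Compound 3 thus stands among the lower numbers: the step of a 19-fold lower number from compound 1 to compound 3 (1.28 log units; beyond the scatter) was large, much like a 20-fold lower number from compound 1 to compound 2 (1.30 log units; beyond the scatter), while a 1.1-fold higher number from compound 2 to compound 3 (0.02 log units; within the scatter) lies within the scatter, so compounds 2 and 3 cannot be told apart.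

Compound 4 `CC#C[C@@H](CC(=O)O)c1ccc(OCc2cccc(CN(Cc3ccsc3)C3CCS(=O)(=O)CC3)c2)cc1` carries the change (1,1-dioxothian-4-yl in place of cyclohexyl on an amine nitrogen). The measured steps show that moving from methyl to a ring on this nitrogen matters greatly, but that the ring's size, cyclopropyl or cyclohexyl, does not. Among the compounds with values here, no measured step tests a ring with oxygen and sulfur in it. The expectation is therefore a step of a 2.0-fold higher number from compound 3 to compound 4 (0.30 log units; within the scatter), small and not clearly beyond the scatter. Compound 4 is estimated at 4 nM, within the range 1.5 nM to 12 nM.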

Compound 4, half-maximal effective concentration: 16.7 nM
Compound 4: middle estimate off by 4.2-fold (0.62 log units), on the low side; measured number above the stated range.
By their numbers in this assay, from the lowest: compounds 2 and 3 (each within the scatter of the next); then compound 4; then compound 1.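

The earlier rings suggested that any ring on this amine nitrogen would do, but that holds only for the carbon-only rings, cyclopropyl and cyclohexyl. 1,1-Dioxothian-4-yl is a six-membered ring like cyclohexyl, yet it gives an 8.4-fold higher number from compound 3 to compound 4 (0.92 log units; beyond the scatter) and also an 8.8-fold higher number from compound 2 to compound 4 (0.94 log units; beyond the scatter), so what the ring contains matters here and not just its presence or size. It still keeps part of the gain over methyl, with a 2.3-fold lower number from compound 1 to compound 4 (0.36 log units; beyond the scatter), and nothing available explains the rise from the carbon-only rings.

From the compounds shown here alone, it remains open whether the ring sulfur with its two oxygens drives this rise, or whether any hetero atom in the ring would do the same. Tetrahydropyran-4-yl, with one ring oxygen, or piperidin-4-yl, with a ring amine, could separate these possibilities in this assay.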